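A few compounds are considered here, and "the series" means these few. Any claim that something is new, unique, unknown or untested is made for them only; others in the source may bear on it.

Series notes on a functional assay on HepG2 cells (Homo sapiens) for antiproliferative activity, read by MTT assay, with a stated time of 48 h; on this read-out lower numbers stand for stronger inhibition and higher numbers for weaker inhibition. Compound 1 (`CCn1cc(-c2ccc(F)cc2)c(=O)c2cc(F)c(N3CCNCC3)cc21`) gives 56200 nM, compound 2 (`CCn1cc(-c2ccc(Cl)cc2)c(=O)c2cc(F)c(N3CCNCC3)cc21`) gives 24000 nM and compound 3 (`CCn1cc(-c2ccc(C#N)cc2)c(=O)c2cc(F)c(N3CCNCC3)cc21`) gives 12600 nM. Compound 2 stands clearly under compound 1 and level with compound 3 within the scatter, as shown by a 2.3-fold lower number from compound 1 to compound 2 (0.37 log units; beyond the scatter) and by a 1.9-fold lower number from compound 2 to compound 3 (0.28 log units; within the scatter). The widest measured step is cyano in place of fluoro, a 4.5-fold lower number from compound 1 to compound 3 (0.65 log units; beyond the scatter).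

Compound 4 (`O=c1c(-c2ccc(Cl)cc2)cn(C2CC2)c2cc(N3CCNCC3)c(F)cc12`) keeps the 4-chlorophenyl group of compound 2 and differs in one place: cyclopropyl in place of ethyl on an aromatic nitrogen. Among the measured compounds shown here, no measured step changes the group on the aromatic nitrogen, since all three exchange only the substituent on the aromatic carbon. They therefore give a scale of step size but no direction. In this assay, no step beyond the scatter is expected, and the modest 2.3-fold lower number from compound 1 to compound 2 (0.37 log units; beyond the scatter) serves as a rough outer size. The estimated change is a 1.2-fold lower number from compound 2 to compound 4 (0.08 log units; within the scatter). For compound 4 the expected value is 20000 nM, with an estimated range from 8000 nM to 50000 nM.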

Compound 4, half-maximal inhibitory concentration: 8020 nM
Compound 4: the middle estimate sits 2.5-fold (0.40 log units) above what was measured; low and high end bracket the measured number.
By their numbers in this assay, from the lowest: compounds 4, 3 and 2 (each within the scatter of the next, the first and the last beyond it); then compound 1.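

In this assay, the group on the aromatic nitrogen proves to be a position that responds: cyclopropyl in place of ethyl gives a 3.0-fold lower number from compound 2 to compound 4 (0.48 log units; beyond the scatter), a step beyond the scatter. Among the compounds shown here, the earlier steps only exchanged the substituent on the aromatic carbon, so this is the first direction seen at the nitrogen, and it runs towards the lower number, although it rests on a single pair carrying the 4-chlorophenyl group. Nothing on hand accounts for the step, so the result stands as an observation only.

The compounds shown leave open whether the same exchange gives a similar step with the 4-fluorophenyl or 4-cyanophenyl group in place. They also leave open how a larger ring such as cyclobutyl, or a longer chain such as propyl, would read on this nitrogen.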